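Swapping the butylcarbonyl of compound 2 for a furan-2-yl carbonyl

A few compounds are considered here, and "the series" means these few. Any claim that something is new, unique, unknown or untested is made for them only; others in the source may bear on it.

Of the compounds shown here, two of a shared core have been measured in a functional assay on A-375 cells (Homo sapiens) for cytotoxicity, read by MTT assay; on this read-out higher numbers stand for weaker inhibition and lower numbers for stronger inhibition. Compound 1, `C=CCOc1cc(/C=C/C(=O)c2ccc(OC)c3c2OC(C)(C)C=C3)ccc1OC`, gives only a limit, > 10000 nM, in this assay. Compound 1 thus stands at the limit of > 10000 nM in this assay, at which 1 of the 2 values shown sits. Among the compounds with values here, compound 2, `CCCCC(=O)Oc1cc(/C=C/C(=O)c2ccc(OC)c3c2OC(C)(C)C=C3)ccc1OC`, gives 220 nM in this assay and is the only compound with a number rather than a limit. Within the data shown here, the one measured step, an at least 45-fold lower number from compound 1 to compound 2 (1.65 log units; beyond the scatter), is large and concerns the exchange of an allyl for a butylcarbonyl on an oxygen on an aromatic ring.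

Compound 3, `COc1ccc(/C=C/C(=O)c2ccc(OC)c3c2OC(C)(C)C=C3)cc1OC(=O)c1ccco1`, is not yet measured. It differs from compound 2 by furan-2-yl in place of butyl on a carbonyl carbon. The measured step does not bear on this change directly: it tells what happens when the butylcarbonyl enters in place of allyl, not what happens when the butyl on that carbonyl carbon is replaced by furan-2-yl. Compound 3 keeps the carbonyl on the oxygen that distinguishes compound 2 from compound 1, so a step no larger than the scatter is expected, a 1.4-fold higher number from compound 2 to compound 3 (0.13 log units; within the scatter). Compound 3 is therefore estimated at 300 nM, between 90 nM and 1000 nM.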

Compound 3, half-maximal inhibitory concentration: 680 nM
Compound 3: middle estimate off by 2.3-fold (0.36 log units), on the low side; measured number inside the range.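

In this assay, the group on the carbonyl carbon turns out to matter in its own right: furan-2-yl in place of butyl gives a 3.1-fold higher number from compound 2 to compound 3 (0.49 log units; beyond the scatter), a modest change, though one beyond the usual scatter, and one that the comparison of compound 1 with compound 2 could not reveal. Yet the large gain over the allyl ether is not confined to the butylcarbonyl group, since (furan-2-yl)carbonyl in place of allyl on the same oxygen on an aromatic ring gives an at least 14-fold lower number from compound 1 to compound 3 (1.16 log units; beyond the scatter), so among these three compounds both groups with a carbonyl on that oxygen give far lower numbers than allyl. Compound 1 is held only as a limit, so the full size of that step stays unknown: the limit of > 10000 nM in this assay, at which 1 of the 3 values shown sits.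

The compounds shown leave open whether the carbonyl itself accounts for the gain, a question that an amide nitrogen in place of the ester oxygen, or a plain propyl chain on that oxygen, would address. They also leave open how far the number moves on the carbonyl carbon with a phenyl ring, a longer chain or an amine-bearing chain in place of butyl.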